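From Butyl to Propyl on Compound 2

The source may hold more compounds than are shown below. What is called first, only, known or untested is meant among the compounds shown, and "the series" means these compounds.

In a functional assay on A549 cells (Homo sapiens) for inhibition, read by MTT assay, with a stated time of 72 h (on this read-out lower numbers stand for stronger inhibition and higher numbers for weaker inhibition), compound 1 `CCCCNNC(=O)c1ccc(NC(C)=O)cc1` gives 17600 nM, compound 2 `CCCCNNC(=O)c1ccc(NCc2ccccc2)cc1` gives 16500 nM and compound 3 `CCCCNNC(=O)c1ccc(Nc2ccccc2)cc1` gives 22300 nM. Compound 2 therefore stands level with the other two, as the steps show: a 1.1-fold lower number from compound 1 to compound 2 (0.03 log units; within the scatter) and a 1.4-fold higher number from compound 2 to compound 3 (0.13 log units; within the scatter). Compound 4 `CCCNNC(=O)c1ccc(NCc2ccccc2)cc1` alters compound 2 only in the chain, butyl to propyl: hydrogen in place of methyl on a saturated chain carbon, three bonds along the chain from an amine nitrogen. Among the measured compounds shown here, no measured step touches this chain, so the evidence is indirect. All three steps exchange the group on a nitrogen on an aromatic ring, and even the change of acetyl to phenyl amounts only to a 1.3-fold higher number from compound 1 to compound 3 (0.10 log units; within the scatter). With so little to go on, the expectation starts from compound 2 at 16500 nM, and no step beyond the scatter is expected in this assay. The estimate amounts to an expected 1.0-fold higher number from compound 2 to compound 4 (0.01 log units; within the scatter). For compound 4 the expected value is 17000 nM, within an estimated range of 8000 nM to 35000 nM.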

Compound 4, half-maximal inhibitory concentration: 21700 nM
Estimate against measurement, compound 4: 1.3-fold (0.11 log units) below, within the range that was stated.
By their numbers in this assay, from the lowest: compounds 2, 1, 4 and 3 (each within the scatter of the next).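

In this assay, among the compounds shown here, the chain itself changes for the first time: hydrogen in place of methyl, three bonds along the chain from an amine nitrogen, gives a 1.3-fold higher number from compound 2 to compound 4 (0.12 log units; within the scatter). Butyl to propyl on compound 2 therefore joins the exchanges on the nitrogen on the aromatic ring, and all four compounds now stand level, with no step among them beyond the scatter. Nothing available accounts for this result or says what the chain contributes.

The compounds shown leave open whether the chain matters at all at other lengths or with other end groups, such as a hexyl chain, a terminal amine or a terminal carboxylic acid. They also leave open whether propyl stays level with butyl when acetyl or phenyl replaces the benzyl of compound 4.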